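Alkyne-linked aryl groups and growth inhibition in breast cancer cells

The source may report more compounds than this note shows. Statements on the series, on what has been measured and on what is new or still open speak of the compounds shown alone.

The measured compounds in this study:
Compound 1 `COC(=O)c1sc2cc(C#Cc3cccc(N)c3)cnc2c1N`: in a functional assay on MCF7 cells (Homo sapiens) for inhibition, read by sulforhodamine B assay, with a stated time of 48 h (on this read-out higher numbers stand for weaker inhibition of growth and lower numbers for stronger inhibition of growth), compound 1 gives 10800 nM.
Compound 2 `COC(=O)c1sc2cc(C#Cc3ccccc3F)cnc2c1N`: compound 2 gives only a limit of the assay, > 150000 nM.
Compound 3 `COC(=O)c1sc2cc(C#Cc3cccc(OC)c3)cnc2c1N`: compound 3 gives 33400 nM.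

Among the two actual numbers, compound 1 stands lowest, and its nearest neighbour is compound 3, with a 3.1-fold higher number from compound 1 to compound 3 (0.49 log units; beyond the scatter). Compound 2 sits at the limit of > 150000 nM in this assay, at which 1 of the 3 values shown sits, so it is a limit rather than a number.

Compound 4 `COC(=O)c1sc2cc(C#Cc3ccc(F)cc3)cnc2c1N` has not yet been measured. It differs from compound 1 by 4-fluorophenyl in place of 3-aminophenyl on a triple-bonded carbon.

For the measured compounds named here, two measured steps bear on this change. The exchange of the aromatic group on the triple-bonded carbon for a fluorophenyl gave an at least 13-fold higher number from compound 1 to compound 2 (1.14 log units; beyond the scatter), though that fluorophenyl was a 2-fluorophenyl, not the 4-fluorophenyl entering here. The loss of the amino group on the aromatic carbon gave a 3.1-fold higher number from compound 1 to compound 3 (0.49 log units; beyond the scatter). Both point in the same direction, toward a higher number for compound 4 than for compound 1, with a size that is expected to lie somewhere between the modest and the large step seen.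

Compound 4 is therefore expected to give about 40000 nM, with a likely range from 12000 nM to 150000 nM, which is estimated to correspond to a 3.7-fold higher number from compound 1 to compound 4 (0.57 log units; beyond the scatter).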

Compound 4, concentration for 50% growth inhibition: 29000 nM
The estimate for compound 4 lay 1.4-fold (0.14 log units) above the measured number; low and high end bracket the measured number.
By their numbers in this assay, from the lowest: compound 1; then compounds 4 and 3 (each within the scatter of the next). At a limit, above all of these: compound 2.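

In this assay, the new compound shows that a fluorophenyl on the triple-bonded carbon is not bound to lose as much as the first example suggested: the exchange for 3-aminophenyl gives a 2.7-fold higher number from compound 1 to compound 4 (0.43 log units; beyond the scatter), whereas 4-fluorophenyl in place of 2-fluorophenyl gives an at least 5.1-fold lower number from compound 2 to compound 4 (0.71 log units; beyond the scatter), so the two fluorophenyl groups are clearly separated and the outcome depends on which one enters. Compound 2 gives a limit and not a number: the limit of > 150000 nM in this assay, at which 1 of the 4 values shown sits. For the compounds shown here, the exchange of 3-methoxyphenyl for 4-fluorophenyl gives a 1.2-fold lower number from compound 3 to compound 4 (0.06 log units; within the scatter), so these two groups cannot be told apart here, and compound 1, with 3-aminophenyl, remains the only compound whose number lies beyond the scatter below all the others.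

The compounds shown leave open whether the lower number of compound 1 belongs to the amino group itself, or would also come with 3-hydroxyphenyl or 4-aminophenyl on the triple-bonded carbon, and whether 3-fluorophenyl would fall with compound 4 or with compound 2. They also leave open how these groups would behave with a carboxylic acid in place of the ester on the shared core.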